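The source may hold more compounds than are shown below. What is called first, only, known or untested is meant among the compounds shown, and "the series" means these compounds.

Compound 1 `COc1cccc(/C=C2\CCC/C(=C\c3ccc(Cl)cc3Cl)C2=O)c1OC`: in a functional assay on A549 cells (Homo sapiens) for cytotoxicity, read by MTT assay, with a stated time of 72 h (a higher number here means a weaker inhibitor, a lower number a stronger inhibitor), compound 1 gives > 20000 nM, a limit of the assay.
Compound 2 `COc1cccc(/C=C2\CCC/C(=C\c3ccc(Cl)c(Cl)c3)C2=O)c1OC`: in this assay compound 2 gives > 20000 nM, again a limit.
Compound 3 `COc1ccc(/C=C2\CCC/C(=C\c3ccc(Cl)cc3Cl)C2=O)cc1OC`: in this assay compound 3 gives > 20000 nM, likewise a limit.

Compound 1 and compound 2 differ only by 3,4-dichlorophenyl in place of 2,4-dichlorophenyl on a double-bonded chain carbon bound to a double-bonded ring carbon, and the step between them in this assay is a step that the two limits leave unreadable from compound 1 to compound 2. The cores of compound 1 and compound 3 differ, but that difference is not broken down here. Compound 4 `COc1ccc(/C=C2\CCC/C(=C\c3ccc(Cl)c(Cl)c3)C2=O)cc1OC` has not been measured; it stands to compound 3 as compound 2 stands to compound 1, by the same change, (3,4-dichlorophenyl in place of 2,4-dichlorophenyl on a double-bonded chain carbon bound to a double-bonded ring carbon). Since (the limit of > 20000 nM in this assay, at which 3 of the 3 values shown sit), the earlier step gives no readable size to carry over. Compound 4 is nevertheless expected to remain at the limit, because of the limit of > 20000 nM in this assay, at which 3 of the 3 values shown sit. The step from compound 3 to compound 4 is accordingly estimated as a step that the limit leaves unreadable from compound 3 to compound 4. For compound 4 the estimated value in this assay is 30000 nM, expected to lie between 12000 nM and 100000 nM.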

Compound 4, half-maximal inhibitory concentration: 6900 nM
Beside the measured number, compound 4's estimate is 4.3-fold (0.64 log units) above it; measured number below the stated range.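

On the core of compound 3, 3,4-dichlorophenyl in place of 2,4-dichlorophenyl gives in this assay an at least 2.8-fold lower number from compound 3 to compound 4 (0.46 log units; beyond the scatter), so the change has a readable effect on this core. The size of this step is only a lower bound, and a single pair on a single core establishes no trend. The same change on the core of compound 1 cannot be read, so whether the effect carries from one core to the other is not shown, because both ends of that pair are limits: the limit of > 20000 nM in this assay, at which 3 of the 4 values shown sit.

The compounds shown leave open how an amine or a carboxylic acid on the phenyl ring would read in this assay. Also open, on these data alone, is what a longer chain in place of the methoxy groups would do.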